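Amide Variation in a Series Without Measurable Receptor Inhibition

The source may report more compounds than this note shows. Statements on the series, on what has been measured and on what is new or still open speak of the compounds shown alone.

Compound 1 `CS(=O)(=O)c1ccc(C(=O)N2CCC(C(=O)N3CCc4ccccc43)CC2)cc1[N+](=O)[O-]`: > 60000 nM
Compound 2 `CS(=O)(=O)c1ccc(C(=O)NCCC(=O)N2CCCCC2)cc1[N+](=O)[O-]`: > 60000 nM
Compound 3 `CS(=O)(=O)c1ccc(C(=O)NCC(=O)N2CCCCC2)cc1[N+](=O)[O-]`: > 60000 nM

In an assay on isolated protein for inhibition of vitamin D3 receptor (Homo sapiens), read by fluorescence polarization (a higher number here means a weaker inhibitor, a lower number a stronger inhibitor), compound 1 reaches only a limit of the assay, > 60000 nM. Compound 2 also gives only a limit in this assay, > 60000 nM. Compound 3 likewise gives no number but a limit, > 60000 nM. Among the compounds with values here, compound 3 therefore stands nowhere distinguishable from the other two: all three sit at the limit of > 60000 nM in this assay, at which 3 of the 3 values shown sit, and no step between measured compounds that differ in one place can be read off.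

Compound 4 `CC(C)N(C(=O)CNC(=O)c1ccc(S(C)(=O)=O)c([N+](=O)[O-])c1)C(C)C` differs from compound 3 in one place: diisopropylamino in place of piperidin-1-yl on a carbonyl carbon. Within the data shown here, because compound 3 and its neighbours all sit at the limit of > 60000 nM in this assay, at which 3 of the 3 values shown sit, no measured step gives a size to expect; the expected step from compound 3 to compound 4 in this assay, a number no higher from compound 3 to compound 4 (the limit leaves the size open), is none beyond the scatter. Compound 4 is estimated at 60000 nM, with a range from 20000 nM to 200000 nM, most likely again reported only as a limit.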

Compound 4, half-maximal inhibitory concentration: > 60000 nM
Compound 4: only a limit was reported; the forecaster's own chance of this, stated with the estimate: 90%; the middle value sits exactly at the limit.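

In this assay compound 3 and compound 4 both give only a limit and not a number, so no step between them can be read: the limit of > 60000 nM in this assay, at which 4 of the 4 values shown sit.

The four compounds shown leave open what their actual values are and whether any change in the amide part gives measurable inhibition.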